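A few compounds are considered here, and "the series" means these few. Any claim that something is new, unique, unknown or untested is made for them only; others in the source may bear on it.

Measured so far:
compound 1 `CN1CCC(c2ccc3c(c2)oc(=O)n3C(=O)NCCCCc2ccc(F)cc2)CC1` — 94 nM
compound 2 `CCCCCNC(=O)n1c(=O)oc2cc(C3CCN(C)CC3)ccc21` — 396 nM

Both numbers come from an assay on HEK293 cells for inhibition of acid ceramidase (Homo sapiens), read by fluorescence, with stated times of 10 min and 3 h; a lower number here means a stronger inhibitor, a higher number a weaker inhibitor. Compound 2 stands at the higher of the two numbers; compound 1 gives the lower one. Within the data shown here, the single measured step, methyl in place of 4-fluorophenyl on a saturated chain carbon four bonds along the chain from an amide-type nitrogen, reads a 4.2-fold higher number from compound 1 to compound 2 (0.62 log units; beyond the scatter), a modest step beyond the scatter.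

Compound 3 `CN1CCC(c2ccc3c(c2)oc(=O)n3C(=O)NCCOCc2ccccc2)CC1` is not yet measured. Against compound 2 it shows (benzyloxy in place of propyl on a saturated chain carbon, two bonds along the chain from an amide-type nitrogen). This returns an aromatic ring to the chain, but through an oxygen and two bonds along the chain from the amide-type nitrogen rather than four. Among the measured compounds shown here, the only step that bears on it is the loss of the ring, a 4.2-fold higher number from compound 1 to compound 2 (0.62 log units; beyond the scatter); a move back toward lower numbers is therefore expected, its size uncertain given the different linker and place. Compound 3 is estimated at 150 nM (50 nM to 450 nM), an expected step of a 2.6-fold lower number from compound 2 to compound 3 (0.42 log units; beyond the scatter).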

Compound 3, half-maximal inhibitory concentration in the acid ceramidase assay: 215 nM
The estimate for compound 3 lay 1.4-fold (0.16 log units) below the measured number; the measured number falls inside the stated range.
By their numbers in the acid ceramidase assay, from the lowest: compound 1; then compounds 3 and 2 (each within the scatter of the next).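

In the acid ceramidase assay, benzyloxy at this place, on a saturated chain carbon two bonds along the chain from an amide-type nitrogen, gives a 1.8-fold lower number from compound 2 to compound 3 (0.27 log units; within the scatter), so an aromatic ring held through an oxygen does not separate compound 3 from the ringless chain of compound 2. The step of a 2.3-fold higher number from compound 1 to compound 3 (0.36 log units; beyond the scatter) shows that an aromatic ring on the chain is not enough by itself to match compound 1. In a physicochemical assay for solubility, read by HPLC, in phosphate buffer, measured as kinetic solubility, with a stated time of 1 h, at pH 7.4, tested at 250 uM (on this read-out higher numbers stand for higher solubility and lower numbers for lower solubility), compound 2 gives 240000 nM and compound 3 gives 73000 nM. The same change from propyl to benzyloxy does register in the physicochemical assay: the measured solubility of compound 2, 240000 nM, and of compound 3, 73000 nM, a 3.3-fold lower number (0.52 log units; beyond the scatter)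

Compound 1 and compound 3 differ in the chain oxygen, the fluorine and the place of the ring all at once, so which of these accounts for their gap stays open. Also open, going by these compounds, is how a longer chain carrying an amine or a carboxylic acid at this place would read in the acid ceramidase assay.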